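A few compounds are considered here, and "the series" means these few. Any claim that something is new, unique, unknown or untested is made for them only; others in the source may bear on it.

Measured compounds in a functional assay on cells (Melanoma cell, Homo sapiens) for cytotoxicity, with a stated time of 48 h; on this read-out higher numbers stand for weaker inhibition of growth and lower numbers for stronger inhibition of growth:
- compound 1, `COc1cc2c(/C=C3/C(=O)Nc4ccc(O)cc43)c(Cl)n(Cc3cc(OC)c(OC)c(OC)c3)c2cc1C`: 1450 nM
- compound 2, `COc1cc2c(/C=C3/C(=O)Nc4ccc(Cl)cc43)c(Cl)n(Cc3cc(OC)c(OC)c(OC)c3)c2cc1C`: 2290 nM
- compound 3, `COc1cc2c(cc1C)NC(=O)/C2=C/c1c(Cl)n(Cc2cc(OC)c(OC)c(OC)c2)c2cc(C)c(OC)cc12`: 25100 nM

Compound 3 carries the highest of the three numbers; the gap to compound 2 and the larger gap to compound 1 both lie beyond the scatter, so compound 3 is the weakest growth inhibitor in this set. Among the compounds with values here, the one measured step within the set, a 1.6-fold higher number from compound 1 to compound 2 (0.20 log units; within the scatter), concerns a change on the six-membered aromatic ring of the shared core and stays within the scatter.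

Compound 4, `COc1ccc2c(c1)/C(=C\c1c(Cl)n(Cc3cc(OC)c(OC)c(OC)c3)c3cc(C)c(OC)cc13)C(=O)N2`, differs from compound 3 by hydrogen in place of methyl on an aromatic carbon. Within the data shown here, no measured step touches this position or this kind of change; the step from compound 1 to compound 2 concerns another substituent and another site, so it offers no direct guide. The step from compound 3 to compound 4 is therefore expected to lie within the usual scatter, with no direction that the data can support, and the estimated step is a 1.1-fold lower number from compound 3 to compound 4 (0.06 log units; within the scatter). On that basis compound 4 is expected to give about 22000 nM in this assay, with the range 7000 nM to 60000 nM reflecting the absence of any comparable measured step.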

Compound 4, concentration for 50% growth inhibition: 14800 nM
Compound 4: middle estimate off by 1.5-fold (0.17 log units), on the high side, within the range that was stated.
By their numbers in this assay, from the lowest: compounds 1 and 2 (each within the scatter of the next); then compounds 4 and 3 (each within the scatter of the next).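

In this assay, hydrogen in place of methyl on the aromatic carbon ortho to a methoxy group gives a 1.7-fold lower number from compound 3 to compound 4 (0.23 log units; within the scatter), so compounds 3 and 4 stand level and this position accepts either group without a readable difference. Within the data shown here, compound 4 also links this pair to the earlier compounds: methoxy in place of chloro gives a 6.5-fold higher number from compound 2 to compound 4 (0.81 log units; beyond the scatter), and methyl in place of hydrogen on the oxygen gives a 10-fold higher number from compound 1 to compound 4 (1.01 log units; beyond the scatter). Among these compounds, the hydroxy and chloro compounds had differed only within the scatter, so these two steps are the first sign that the substituent on that aromatic carbon of the shared core can shift growth inhibition, with the methoxy compound 4 giving the higher number.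

Nothing shown accounts for the gap between the methoxy compound and the hydroxy and chloro compounds. From the compounds shown here alone, whether an amine or a carboxylic acid on that aromatic carbon would read with compounds 1 and 2 or with compound 4 stays open, as does whether a longer chain on the oxygen would move the number further.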